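Amide nitrogen substituent: propargyl to fluoroallyl

The compounds below may be only part of what the source reports. "The series", "measured", "known", "first", "only" and "open" are said of these compounds alone.

Compound 2, `C#CCN(CCOC)C(=O)[C@@]1(c2ccsc2)C[C@H]1CN`, carries an ethynyl on a saturated chain carbon bound to an amide-type nitrogen. In an assay on HEK293 cells for inhibition of sodium-dependent dopamine transporter (Homo sapiens) (a higher number here means a weaker inhibitor, a lower number a stronger inhibitor), compound 2 gives only a limit, > 10000 nM. Compound 1, `C=CCN(CCOC)C(=O)[C@@]1(c2ccsc2)C[C@H]1CN`, the vinyl counterpart, likewise gives only a limit in this assay, > 10000 nM. The step that the two limits leave unreadable from compound 1 to compound 2 therefore cannot be read. Both values sit at the limit of > 10000 nM in this assay, at which 2 of the 2 values shown sit.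

Compound 3, `C=C(F)CN(CCOC)C(=O)[C@@]1(c2ccsc2)C[C@H]1CN`, differs from compound 2 by 1-fluoroethenyl in place of ethynyl on a saturated chain carbon bound to an amide-type nitrogen. Going by the values given here, the only measured step at this position, vinyl to ethynyl, is unreadable, so no measured step with a readable size bears on the change to 1-fluoroethenyl. With both measured neighbours at the limit, the expected step that the limit leaves unreadable from compound 2 to compound 3 in this assay is none beyond the scatter. Compound 3 is expected to return only a limit in this assay. The estimate for compound 3 in this assay is 15000 nM, with range 5000 nM to 50000 nM.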

Compound 3, half-maximal inhibitory concentration: > 10000 nM
Compound 3: only a limit was reported; the forecaster's own chance of this, stated with the estimate: 85%; the middle value is on the limit's open side.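

Compound 3 also returns only a limit in this assay, > 10000 nM, so its steps from compound 1 and compound 2 cannot be read. The compounds shown leave open how vinyl, ethynyl and 1-fluoroethenyl rank in this assay, and which change to the shared core would give a readable value.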